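The source may hold more compounds than are shown below. What is called first, only, known or untested is meant among the compounds shown, and "the series" means these compounds.

Measured so far:
compound 1 `Cc1ccc(C)c(NC(=O)c2ccc(/N=N\c3c[nH]c4ccccc34)cc2)c1` — 29900 nM
compound 2 `O=C(Nc1ccc(Cl)cc1)c1ccc(/N=N\c2c[nH]c3ccccc23)cc1` — 107000 nM

Compound 2 has the highest number of the two in a functional assay on MCF7 cells (Homo sapiens) for inhibition, read by MTT assay, with a stated time of 72 h (a higher number here means a weaker inhibitor, a lower number a stronger inhibitor), the nearest being compound 1, whose number is lower by a 3.6-fold higher number from compound 1 to compound 2 (0.55 log units; beyond the scatter). Compound 3 `O=C(Nc1cccc([N+](=O)[O-])c1)c1ccc(/N=N\c2c[nH]c3ccccc23)cc1` differs from compound 2 by 3-nitrophenyl in place of 4-chlorophenyl on an amide-type nitrogen. Going by the values given here, only the step from compound 1 to compound 2 bears on this place, and it was modest. For compound 3 a step of a 1.3-fold lower number from compound 2 to compound 3 (0.13 log units; within the scatter) is expected, within the scatter. The estimate for compound 3 in this assay is 80000 nM, with a range from 25000 nM to 250000 nM.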

Compound 3, half-maximal inhibitory concentration: 51900 nM
Estimate against measurement, compound 3: 1.5-fold (0.19 log units) above, within the range that was stated.
By their numbers in this assay, from the lowest: compounds 1 and 3 (each within the scatter of the next); then compound 2.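

In this assay the 3-nitrophenyl group gives a step of a 2.1-fold lower number from compound 2 to compound 3 (0.31 log units; beyond the scatter) and so stands apart from 4-chlorophenyl at the amide-type nitrogen, while the step of a 1.7-fold higher number from compound 1 to compound 3 (0.24 log units; within the scatter) does not separate it from 2,5-dimethylphenyl. Compound 2, with 4-chlorophenyl, is thus the weakest of the three, and the other two substituents cannot be told apart here. Nothing available explains this difference. As far as these compounds go, it remains open how an amine or a carboxylic acid on this phenyl ring would read in this assay. From the compounds shown here alone, it also remains open whether a longer chain in place of the ring on this nitrogen would keep or lose the inhibition.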